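4-Fluorophenyl to 4-chlorophenyl: an expected small step

This account rests on a few compounds, and the source may have more. Where it says the series, first, only, none or still open, it means among the compounds named here.

In a functional assay on the whole organism (strain Kunming) with Mus musculus as the target, in the formalin test, with a stated time of 0.5 h (a lower number here means that less compound is needed, a higher number that more compound is needed for the effect), compound 1 (`COc1cc(OC)c(OC)cc1/C=C/COC(=O)/C=C/c1ccccc1Cl`) gives 260 umol/kg and compound 2 (`COc1cc(OC)c(OC)cc1/C=C/COC(=O)/C=C/c1ccc(F)cc1`) gives 117 umol/kg, the lower of the two numbers. Compound 3 (`COc1cc(OC)c(OC)cc1/C=C/COC(=O)/C=C/c1ccc(Cl)cc1`) differs from compound 2 by chloro in place of fluoro on an aromatic carbon, with chloro in place of fluoro on an aromatic carbon, para to a large group. Within the data shown here, the only measured step, a 2.2-fold lower number from compound 1 to compound 2 (0.35 log units; beyond the scatter), is modest and changes the halogen and its place together, so no measurement isolates this swap. Only a small shift, within the scatter, is expected, a 1.1-fold higher number from compound 2 to compound 3 (0.03 log units; within the scatter). For compound 3 the estimated value is 125 umol/kg, with an expected range of 55 umol/kg to 260 umol/kg.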

Compound 3, dose for half-maximal effect: 278 umol/kg
Estimate against measurement, compound 3: 2.2-fold (0.35 log units) below, and the stated range ends below it.
By their numbers in this assay, from the lowest: compound 2; then compounds 1 and 3 (each within the scatter of the next).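

The halogen swap is now isolated at this aromatic carbon, para to a large group: with the place held, chloro in place of fluoro gives a step beyond the scatter in this assay (a 2.4-fold higher number from compound 2 to compound 3 (0.38 log units; beyond the scatter)). With the halogen held as chloro, the 4-chlorophenyl and 2-chlorophenyl groups cannot be told apart (a 1.1-fold higher number from compound 1 to compound 3 (0.03 log units; within the scatter)), so among these compounds the lower number of compound 2 goes with fluoro, not with the place of chloro. No evidence is available on what lies behind this step. The compounds shown leave open where a methoxy group, a nitrile or an amine on the same carbon would fall, and whether fluoro keeps its lower number at another place on the ring.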